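Bromo to hydrogen on the pendant phenyl of compound 3

The source may report more compounds than this note shows. Statements on the series, on what has been measured and on what is new or still open speak of the compounds shown alone.

Three measured compounds share one core and differ only in the group carried on the pendant phenyl ring. Compound 1 `O=C(Nc1ccc(Oc2ccnc3[nH]ccc23)c(F)c1)c1nn(-c2ccc(Cl)cc2)ccc1=O` carries chloro; in a functional assay on MCF7 cells (Homo sapiens) for cytotoxicity, read by MTT assay, with a stated time of 72 h (on this read-out lower numbers stand for stronger inhibition and higher numbers for weaker inhibition), compound 1 gives a limit rather than a number, > 60000 nM, as noted in the limit of > 60000 nM in this assay, at which 1 of the 3 values shown sits. Compound 2 `COc1ccc(-n2ccc(=O)c(C(=O)Nc3ccc(Oc4ccnc5[nH]ccc45)c(F)c3)n2)cc1` carries methoxy, and in this assay compound 2 gives 55400 nM. Compound 3 `O=C(Nc1ccc(Oc2ccnc3[nH]ccc23)c(F)c1)c1nn(-c2ccc(Br)cc2)ccc1=O` carries bromo, and in this assay compound 3 gives 11600 nM, the lowest of the two numbers shown. The measured steps are an at least 5.1-fold lower number from compound 1 to compound 3 (0.71 log units; beyond the scatter), a 4.8-fold lower number from compound 2 to compound 3 (0.68 log units; beyond the scatter) and an at least 1.0-fold lower number from compound 1 to compound 2 (0.03 log units; that floor lies within the scatter).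

Compound 4 `O=C(Nc1ccc(Oc2ccnc3[nH]ccc23)c(F)c1)c1nn(-c2ccccc2)ccc1=O` differs from compound 3 by hydrogen in place of bromo on an aromatic carbon. Among the compounds with values here, none of the measured steps removes the group altogether, but both steps that reach compound 3 show that the bromo variant sits at the low end and that swapping the group moves the read-out by a modest margin, so a higher number is expected for hydrogen. Compound 4 is therefore estimated at 45000 nM in this assay, within 15000 nM to 150000 nM, an expected step of a 3.9-fold higher number from compound 3 to compound 4 (0.59 log units; beyond the scatter).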

Compound 4, half-maximal inhibitory concentration: 34900 nM
The estimate for compound 4 lay 1.3-fold (0.11 log units) above the measured number; measured number inside the range.
By their numbers in this assay, from the lowest: compound 3; then compounds 4 and 2 (each within the scatter of the next). At a limit, above all of these: compound 1.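

In this assay, within the data shown here, the unsubstituted phenyl gives the first reading with no group at this ring position: a 3.0-fold higher number from compound 3 to compound 4 (0.48 log units; beyond the scatter), so bromo keeps the lower number against hydrogen as well as against methoxy. Hydrogen and methoxy do not separate, with a 1.6-fold lower number from compound 2 to compound 4 (0.20 log units; within the scatter), so of the two groups with a measured number, only bromo stands apart from the bare phenyl. Chloro cannot be placed against hydrogen, with an at least 1.7-fold lower number from compound 1 to compound 4 (0.23 log units; that floor lies within the scatter), and compound 1 stands at a limit rather than a number: the limit of > 60000 nM in this assay, at which 1 of the 4 values shown sits.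

The compounds shown leave open whether the gain over hydrogen is particular to bromo or would also appear with iodo on this aromatic carbon. They also leave open what an amine or a carboxylic acid would give there.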